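A Piperazine Exchange in a Narrow Band

A few compounds are considered here, and "the series" means these few. Any claim that something is new, unique, unknown or untested is made for them only; others in the source may bear on it.

In a functional assay on SK-OV-3 cells (Homo sapiens) for cytotoxicity, read by MTT assay, with a stated time of 3 days (on this read-out higher numbers stand for weaker inhibition and lower numbers for stronger inhibition), three compounds sharing one core lie close together. Compound 1 `CNc1nc(SCc2nc3ccccc3[nH]2)nc(-c2ccccc2)c1C#N` gives 3 nM, compound 2 `N#Cc1c(Nc2ccccn2)nc(SCc2nc3ccccc3[nH]2)nc1-c1ccccc1` gives 5.81 nM, and compound 3 `N#Cc1c(NC(N)=S)nc(SCc2nc3ccccc3[nH]2)nc1-c1ccccc1` gives 7.81 nM. Compound 3 therefore stands at the upper end of this band, within the scatter of compound 2 but not of compound 1.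

The next compound, compound 4 `N#Cc1c(-c2ccccc2)nc(SCc2nc3ccccc3[nH]2)nc1N1CCNCC1`, carries piperazin-1-yl on the aromatic carbon in place of the group held there by compound 3: a group of 6 heavy atoms (4 carbon, 2 nitrogen; one six-membered non-aromatic ring with 2 hetero atoms) in place of a group of 4 heavy atoms (1 carbon, 2 nitrogen, 1 sulfur; no ring), on an aromatic carbon. The measured steps that bear on this also exchange the group at this place: a 1.9-fold higher number from compound 1 to compound 2 (0.29 log units; within the scatter), a 2.6-fold higher number from compound 1 to compound 3 (0.42 log units; beyond the scatter) and a 1.3-fold higher number from compound 2 to compound 3 (0.13 log units; within the scatter). Two of these stay within the scatter, and the third is modest. For the measured compounds named here, no measured compound has a non-aromatic ring at this place, so the evidence is indirect. No shift beyond the scatter is thus expected in this assay, in either direction. The expected change is a 1.0-fold higher number from compound 3 to compound 4 (0.01 log units; within the scatter). For compound 4 the estimated value is 8 nM, with an expected range from 2.5 nM to 30 nM.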

Compound 4, half-maximal inhibitory concentration: 2.63 nM
Compound 4: the middle estimate sits 3.0-fold (0.48 log units) above what was measured; low and high end bracket the measured number.
By their numbers in this assay, from the lowest: compounds 4, 1, 2 and 3 (each within the scatter of the next, the first and the last beyond it).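

In this assay the piperazin-1-yl group, the first non-aromatic ring at this aromatic carbon, costs nothing: a 3.0-fold lower number from compound 3 to compound 4 (0.47 log units; beyond the scatter) and a 2.2-fold lower number from compound 2 to compound 4 (0.34 log units; beyond the scatter) are both modest, and a 1.1-fold lower number from compound 1 to compound 4 (0.06 log units; within the scatter) lies within the scatter. The exchange thus shows that this place, next to the ring nitrogen and ortho to the cyano group, accepts a six-membered non-aromatic ring and keeps the number level with that of the much smaller methylamino group of compound 1. Nothing measured here accounts for the drop from compound 3.

The compounds shown leave open whether the second ring nitrogen of piperazin-1-yl matters, which a piperidin-1-yl or morpholin-4-yl group at this place would test. They also leave open how a 4-methylpiperazin-1-yl group or a longer aminoalkyl chain would read here.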